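Swapping dimethylamino for fluoro on a quinazolinone-type core

The source may report more compounds than this note shows. Statements on the series, on what has been measured and on what is new or still open speak of the compounds shown alone.

Measured compounds:
compound 1 `Cc1ccc2nc(-c3ccccc3N(C)C)[nH]c(=O)c2c1`: 21.1%
compound 2 `CCN(CC)c1ccc2nc(-c3ccccc3N(C)C)[nH]c(=O)c2c1`: 0%
compound 3 `Cc1ccc2nc(-c3cccc4ccccc34)[nH]c(=O)c2c1`: "not determined" (no result reported)

In an assay on isolated protein for inhibition of DNA topoisomerase 1 (Homo sapiens), with a stated time of 30 min, tested at 20 uM (on this read-out higher numbers stand for a stronger effect at the one concentration tested and lower numbers for a weaker effect), compound 1 gives 21.1%, the higher of the two numbers available. For the measured compounds named here, the only single-place change measured so far is a number 21.1 percentage points lower from compound 1 to compound 2 (beyond the scatter), where compound 2 gives 0%. Compound 3 gives "not determined" (no result reported), carries no number and cannot be placed.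

Compound 4 `Cc1ccc2nc(-c3ccccc3F)[nH]c(=O)c2c1` differs from compound 1 in one place: fluoro in place of dimethylamino on an aromatic carbon. Going by the values given here, no measured step touches this group; the step from compound 1 to compound 2 alters the methyl on the other ring and so does not bear directly on the change to compound 4. Among the compounds with values here, what the data show is only that the core of compound 1 yields a modest read-out that one substitution elsewhere can remove. Within the data shown here, with no step on the dimethylamino itself, the expectation for compound 4 is a number somewhat lower than compound 1 but possibly within the scatter, a step of a number 9.1 percentage points lower from compound 1 to compound 4 (within the scatter). Compound 4 is therefore estimated at 12%, with a range from 0% to 30%.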

Compound 4, a percentage reported as inhibition, at one concentration (the size of the read-out at that concentration, not a potency): 36.3%
Compound 4: the middle estimate sits 24.3 percentage points below what was measured; measured number above the stated range.
By their numbers in this assay, from the lowest: compound 2; then compound 1; then compound 4.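

For the compounds shown here, this is the first measured change on the aromatic ring that carries the dimethylamino group, and in this assay it gives a number 15.2 percentage points higher from compound 1 to compound 4 (beyond the scatter) as a modest but real rise. The dimethylamino group is therefore not needed for a read-out on this core, and the earlier single drop on the other ring no longer stands alone: the read-out on the shared core can move up as well as down. Nothing measured here says what lies behind the rise.

As far as these compounds go, whether the gain belongs to fluoro itself or only to the loss of dimethylamino stays open, and chloro, methoxy or plain hydrogen at this place would help separate the two. Also open, from the compounds shown here alone, is whether fluoro would keep its gain with diethylamino in place of the methyl on the other ring.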